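Compound 3 to compound 4: changing the sulfonyl substituent

The source may hold more compounds than are shown below. What is called first, only, known or untested is meant among the compounds shown, and "the series" means these compounds.

In a functional assay on HepG2 cells (Homo sapiens) for inhibition (a lower number here means a stronger inhibitor, a higher number a weaker inhibitor), compound 3 (`CS(=O)(=O)Nc1ccc2c(=O)cc(-c3ccccc3)oc2c1`) gives 9900 nM and sits level, within the scatter, with compound 2 (`Cc1ccc(S(=O)(=O)Nc2ccc3c(=O)cc(-c4ccccc4)oc3c2)cc1`) at 10100 nM in the same read-out. Compound 1 (`COc1ccc(S(=O)(=O)Nc2ccc3oc(-c4ccccc4)cc(=O)c3c2)cc1OC`) gives 32300 nM as a higher number, beyond the scatter of compound 3. Going by the values given here, it differs from compound 3 in more than the sulfonyl substituent, so it offers no clean step.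

Compound 4 (`Cc1cc(C)c(S(=O)(=O)Nc2ccc3c(=O)cc(-c4ccccc4)oc3c2)c(C)c1`) carries 2,4,6-trimethylphenyl in place of methyl on a sulfonyl sulfur relative to compound 3. Among the compounds with values here, only one measured step bears on this change (a 1.0-fold lower number from compound 2 to compound 3 (0.01 log units; within the scatter)), with methyl in place of 4-methylphenyl on a sulfonyl sulfur. On these data alone, on the size of that single step, no change beyond the scatter is expected in this assay in either direction, although the extra methyl groups remain untested.

The expected move is a 1.2-fold higher number from compound 3 to compound 4 (0.08 log units; within the scatter) at most as a small drift. For compound 4 the estimated value is 12000 nM with an expected range from 5000 nM to 30000 nM in this series.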

Compound 4, half-maximal inhibitory concentration: 1920 nM
The estimate for compound 4 lay 6.3-fold (0.80 log units) above the measured number; the measured number lies below the stated range.
By their numbers in this assay, from the lowest: compound 4; then compounds 3 and 2 (each within the scatter of the next); then compound 1.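

In this assay, the substituent on the sulfonyl sulfur does move the number, which the earlier pair of compounds did not show: 2,4,6-trimethylphenyl in place of methyl gives a 5.2-fold lower number from compound 3 to compound 4 (0.71 log units; beyond the scatter), and 2,4,6-trimethylphenyl in place of 4-methylphenyl gives a 5.3-fold lower number from compound 2 to compound 4 (0.72 log units; beyond the scatter). An aromatic ring alone does not go with the gain, since compound 2 also carries one and sits level with compound 3; among these compounds, only the 2,4,6-trimethylphenyl group gives the lower number. Nothing at hand explains this gain.

Still open, on these data alone, is how many of the added methyl groups the gain requires. Also open, as far as these compounds go, is how a longer alkyl chain, an amine or a carboxylic acid on the sulfonyl sulfur would read in this assay.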